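Replacing tert-butyl on the shared core with a substituted phenyl

The source may hold more compounds than are shown below. What is called first, only, known or untested is meant among the compounds shown, and "the series" means these compounds.

Of the compounds shown here, three built on one shared core have been measured in a functional assay on Jurkat cells for inhibition of nuclear factor NF-kappa-B complex (Homo sapiens); a lower number here means a stronger inhibitor, a higher number a weaker inhibitor. Compound 1 `CCOC(=O)c1cnc(C(C)(C)C)nc1NN1C(=O)C=C(C)C1=O` gives 1000 nM in this assay. Compound 2 `CCOC(=O)c1cnc(-c2ccccc2)nc1NN1C(=O)C=C(C)C1=O` gives 100 nM, while compound 3 `CCOC(=O)c1cnc(-c2csc(C)n2)nc1NN1C(=O)C=C(C)C1=O` gives 8000 nM. Among these three numbers compound 1 holds the second highest; its nearer neighbour is reached by the step of an 8.0-fold higher number from compound 1 to compound 3 (0.90 log units; beyond the scatter), and its further neighbour by the step of a 10-fold lower number from compound 1 to compound 2 (1.00 log units; beyond the scatter).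

Compound 4 `CCOC(=O)c1cnc(-c2ccc(C(F)(F)F)cc2)nc1NN1C(=O)C=C(C)C1=O` is not yet measured. Relative to compound 1 the change is 4-(trifluoromethyl)phenyl in place of tert-butyl on an aromatic carbon.

The step most closely related to this change is a 10-fold lower number from compound 1 to compound 2 (1.00 log units; beyond the scatter), where an aromatic ring of carbon only also replaced tert-butyl on the same carbon of the core. The contrary result of an 8.0-fold higher number from compound 1 to compound 3 (0.90 log units; beyond the scatter) and the large gap an 80-fold higher number from compound 2 to compound 3 (1.90 log units; beyond the scatter) show that not every ring in this position lowers the number, but the ring entering in compound 4 is a six-membered carbon ring like that of compound 2. A step in this assay beyond the scatter, toward a lower number, is therefore expected for compound 4, of about the size a 6.7-fold lower number from compound 1 to compound 4 (0.82 log units; beyond the scatter). Compound 4 is estimated to give 150 nM, within a range from 30 nM to 800 nM.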

Compound 4, half-maximal inhibitory concentration: 400 nM
The estimate for compound 4 lay 2.7-fold (0.43 log units) below the measured number, within the range that was stated.
By their numbers in this assay, from the lowest: compound 2; then compound 4; then compound 1; then compound 3.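

In this assay, the 4-(trifluoromethyl)phenyl group keeps the direction already seen for a phenyl ring on this carbon of the shared core (a 2.5-fold lower number from compound 1 to compound 4 (0.40 log units; beyond the scatter)), so the lower number relative to tert-butyl is not confined to the unsubstituted ring. Going by these compounds alone, what the earlier compounds could not show is that a substituent on the phenyl ring itself also moves the number: trifluoromethyl in place of hydrogen gives a step beyond the scatter (a 4.0-fold higher number from compound 2 to compound 4 (0.60 log units; beyond the scatter)), which gives back part of the gain that compound 2 held over compound 1. Even so, the substituted phenyl ring stays far ahead of the 2-methyl-1,3-thiazol-4-yl group (a 20-fold lower number from compound 3 to compound 4 (1.30 log units; beyond the scatter)), and compound 3 remains the only one of the ring-bearing compounds with a higher number than compound 1.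

Open, going by these compounds, is whether an amine or a methoxy group in the place of the trifluoromethyl group would bring the number back toward that of compound 2 or carry it further away, and whether a chlorine atom would behave as trifluoromethyl does. Nothing measured here accounts for the difference between trifluoromethyl and hydrogen on the phenyl ring.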